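Anilino in place of butylamino on a shared core

A few compounds are considered here, and "the series" means these few. Any claim that something is new, unique, unknown or untested is made for them only; others in the source may bear on it.

Measured compounds:
Compound 2 `CCCCNc1nc(C(C)C)nc2c1cnn2-c1ccccc1`: > 100000 nM
Compound 1 `Cc1nc(Nc2ccccc2)c2cnn(-c3ccccc3)c2n1`: > 100000 nM

In a functional assay on G-361 cells (Homo sapiens) for cytotoxicity, read by sulforhodamine B assay (a lower number here means that less compound is tolerated, a higher number that more compound is tolerated), compound 2 gives > 100000 nM, which is a limit of the assay and not a number. Compound 1 gives > 100000 nM, likewise a limit. For the measured compounds named here, compound 2 therefore stands at the limit of > 100000 nM in this assay, at which 2 of the 2 values shown sit, and nothing among the measured values separates it from compound 1.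

Compound 3 `CC(C)c1nc(Nc2ccccc2)c2cnn(-c3ccccc3)c2n1` differs from compound 2 by phenyl in place of butyl on a nitrogen on an aromatic ring. Going by the values given here, no step between two measured compounds is available to set the size of such a change, so the expectation rests on the two limits alone. Compound 3 is expected to remain at the limit, so the step from compound 2 is estimated as a number no higher from compound 2 to compound 3 (the limit leaves the size open), none beyond the scatter. Compound 3 is estimated at 100000 nM, with a range from 40000 nM to 300000 nM.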

Compound 3, concentration lethal to 50% of the cells: > 100000 nM
Compound 3 ended at the assay's limit; the forecaster's own chance of this, stated with the estimate: 85%; the middle value sits exactly at the limit.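

No step among compound 1, compound 2 and compound 3 can be read in this assay, because all three stand at one limit: the limit of > 100000 nM in this assay, at which 3 of the 3 values shown sit.

The compounds shown leave open whether the change from butylamino to anilino, or from methyl to isopropyl, alters the tolerated concentration at all.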